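A Second Hydroxy on the Core of Compound 3

The compounds below may be only part of what the source reports. "The series", "measured", "known", "first", "only" and "open" are said of these compounds alone.

The study compares three measured compounds and one that awaits measurement. Compound 1 `O=c1cc(/C=C/c2ccc(O)c(O)c2)oc2cc(O)ccc12` and compound 2 `O=c1cc(/C=C/c2ccc(O)c(O)c2)oc2ccccc12` share one core; compound 3 `O=c1cc(/C=C/c2ccc(O)cc2)oc2cccc(O)c12` carries its hydroxy groups on a core joined differently, and the difference between the two cores is not broken down here. In a functional assay, in the absence of a further agent (a lower number here means a stronger inhibitor, a higher number a weaker inhibitor), compound 2 gives 240 nM, compound 1 gives 300 nM and compound 3 gives 1040 nM, the highest number of the three. The step of a 1.3-fold higher number from compound 2 to compound 1 (0.10 log units; within the scatter) is hydroxy in place of hydrogen on an aromatic carbon.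

Compound 4 `O=c1cc(/C=C/c2ccc(O)cc2)oc2cc(O)cc(O)c12` is drawn from compound 3 by the same kind of change, (hydroxy in place of hydrogen on an aromatic carbon); the place differs in that the entering group is meta to a hydroxy group. Because the earlier step of a 1.3-fold higher number from compound 2 to compound 1 (0.10 log units; within the scatter) stayed within the scatter, the step of a 1.2-fold higher number from compound 3 to compound 4 (0.06 log units; within the scatter) is expected to be small as well, with the two cores leaving room for a somewhat larger swing. For compound 4 the estimate in this assay is 1200 nM, with a range from 500 nM to 3000 nM.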

Compound 4, half-maximal inhibitory concentration: 1250 nM
Compound 4: middle estimate off by 1.0-fold (0.02 log units), on the low side, within the range that was stated.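

In this assay, hydroxy in place of hydrogen on an aromatic carbon gives a 1.2-fold higher number from compound 3 to compound 4 (0.08 log units; within the scatter), and this step agrees with the earlier one on the other core: the same change on two cores in this assay, a 1.3-fold higher number (0.10 log units; within the scatter) from compound 2 to compound 1 and a 1.2-fold higher number (0.08 log units; within the scatter) from compound 3 to compound 4, 1.0-fold (0.02 log units) apart, within the scatter of two such steps Across these two pairs, then, the change carries from one core to the other without a step beyond the scatter on either. Within the data shown here, this does not show that the change would stay this small on every core, since it rests on only two pairs, and the place of the entering group differs between them as well as the core.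

The compounds shown leave open whether a group other than hydroxy would also give so small a step at this place, meta to a hydroxy group, on the core of compound 3. A methoxy group, an amine or a carboxylic acid in place of that hydrogen could give a step of quite another size, and nothing here tells either way.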